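Moving the azide around the phenyl ring: working notes

This account rests on a few compounds, and the source may have more. Where it says the series, first, only, none or still open, it means among the compounds named here.

Values so far in a functional assay on HepG2 cells (Homo sapiens) for inhibition; on this read-out higher numbers stand for weaker inhibition and lower numbers for stronger inhibition:
Compound 1 `CCN(CC#Cc1ccccc1N=[N+]=[N-])Cc1cccc(OCc2cc(-c3ccsc3)cs2)c1`: > 100000 nM (a limit of the assay)
Compound 2 `CCN(CC#Cc1cccc(N=[N+]=[N-])c1)Cc1cccc(OCc2cc(-c3ccsc3)cs2)c1`: 540 nM (a measured number)

Within the data shown here, compound 2 holds the only number so far. The entry for compound 1 is a limit. Compound 3 `CCN(CC#Cc1ccc(N=[N+]=[N-])cc1)Cc1cccc(OCc2cc(-c3ccsc3)cs2)c1` is next, with 4-azidophenyl in place of 3-azidophenyl on a triple-bonded carbon. Among the measured compounds shown here, one measured step bears on this change: an at least 180-fold lower number from compound 1 to compound 2 (2.26 log units; beyond the scatter), which is large and also concerns the azidophenyl group. That step shows that the azide position can matter in this assay but gives no direction for this change. A moderately higher number is expected, with wide uncertainty: a 1.5-fold higher number from compound 2 to compound 3 (0.17 log units; within the scatter) is the estimated step. Compound 3 is estimated at 800 nM in this assay, with an expected range from 150 nM to 5000 nM as the working figures.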

Compound 3, half-maximal inhibitory concentration: 2100 nM
For compound 3 the middle estimate is 2.6-fold (0.42 log units) below the measured one; measured number inside the range.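

In this assay the azide position now separates two measured numbers, with a 3.9-fold higher number from compound 2 to compound 3 (0.59 log units; beyond the scatter) as the step. Both measured compounds stand far from the 2-azidophenyl compound, with an at least 47-fold lower number from compound 1 to compound 3 (1.67 log units; beyond the scatter) as the second step, so the high entry stays with 2-azidophenyl alone among the three. The entry for compound 1 is a limit, so its steps give a bound and not a size: the limit of > 100000 nM in this assay, at which 1 of the 3 values shown sits.

Going by these compounds, whether an amine or a carboxylic acid in place of the azide, or a longer chain before the triple-bonded carbon, would keep the activity of compound 2 remains open.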